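A few compounds are considered here, and "the series" means these few. Any claim that something is new, unique, unknown or untested is made for them only; others in the source may bear on it.

In a functional assay on Raji cells (Homo sapiens) for cytotoxicity, with a stated time of 72 h (on this read-out lower numbers stand for an effect already at smaller amounts and higher numbers for an effect only at larger amounts of compound), compound 1 `C=C[C@@](C)(/C=C/c1ccc(O)cc1)CC/C=C(\C)C=O` reaches only a limit, > 26000 nM. Going by the values given here, compound 2 `COc1ccc(/C=C/[C@@](C)(/C=C/c2ccc(O)c(C=O)c2)CCC=C(C)C)cc1` gives 13000 nM, the only actual number so far, so it offers the sole firm reference point. Compound 3 `CCOC(=O)/C(C)=C/c1cc(/C=C/[C@](C)(/C=C/c2ccc(OC)cc2)CCC=C(C)C)ccc1O` keeps the core of compound 2 but carries 2-(ethoxycarbonyl)prop-1-en-1-yl in place of formyl on an aromatic carbon, ortho to a hydroxy group: 2-(ethoxycarbonyl)prop-1-en-1-yl in place of formyl on an aromatic carbon. Among the compounds with values here, no measured pair shows what this change does, so only a modest shift toward lower numbers in this assay is expected. The expected step is a 1.4-fold lower number from compound 2 to compound 3 (0.16 log units; within the scatter). For compound 3 the estimate is 9000 nM, within an expected range of 3000 nM to 26000 nM.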

Compound 3, half-maximal effective concentration: > 26000 nM
Compound 3 was reported as a limit; the forecaster's own chance of this, stated with the estimate: 20%; middle value at least 2.8-fold (0.46 log units) from the limit.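

In this assay, going by these compounds alone, the first reading at this position, with 2-(ethoxycarbonyl)prop-1-en-1-yl in place of formyl on the aromatic carbon, is an at least 2.0-fold higher number from compound 2 to compound 3 (0.30 log units; that floor lies within the scatter) and shows no move toward a lower number. Going by these compounds, the true gap stays unknown, since compound 3 is reported only as a limit: the limit of > 26000 nM in this assay, at which 2 of the 3 values shown sit. What the compounds shown leave open is whether a carboxylic acid or an amine on this carbon would move the number in either direction, and whether keeping the hydroxy group matters.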